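A few compounds are considered here, and "the series" means these few. Any claim that something is new, unique, unknown or untested is made for them only; others in the source may bear on it.

Measured so far in an assay on CHO cells for displacement of a labelled ligand from adenosine receptor A1 (Homo sapiens), read by scintillation counting, with a stated time of 60 min, tested at 10 uM; a higher number here means more inhibition at the concentration tested (going by the name of the read-out), a lower number less inhibition:
compound 1 `CNC(=O)[C@@]12C[C@@H]1[C@@H](n1cnc3c(NC)nc(C#Cc4ccccc4F)nc31)[C@H](O)[C@@H]2O` gives 20%
compound 2 `CNC(=O)[C@@]12C[C@@H]1[C@@H](n1cnc3c(NC)nc(C#Cc4cccc(C(F)(F)F)c4)nc31)[C@H](O)[C@@H]2O` gives 10%

Among the measured compounds shown here, compound 2 is one of only two measured compounds; against compound 1 the step is a number 10 percentage points lower from compound 1 to compound 2 (within the scatter), so the two numbers are not separated. Compound 3 `CNC(=O)[C@@]12C[C@@H]1[C@@H](n1cnc3c(NC)nc(C#Cc4cc5ccccc5o4)nc31)[C@H](O)[C@@H]2O` differs from compound 2 by 1-benzofuran-2-yl in place of 3-(trifluoromethyl)phenyl on a triple-bonded carbon. For the measured compounds named here, no measured step brings in a 1-benzofuran-2-yl group; the single step at the triple-bonded carbon, a number 10 percentage points lower from compound 1 to compound 2 (within the scatter), stayed within the scatter. The expected step is therefore a number 5 percentage points higher from compound 2 to compound 3 (within the scatter), nothing beyond the scatter. Compound 3 is estimated at 15%, between 0% and 40%.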

Compound 3, a percentage reported as inhibition, at one concentration (the size of the read-out at that concentration, not a potency): 13%
For compound 3 the middle estimate is 2 percentage points above the measured one, and the stated range covers the measured number.
By their numbers in this assay, from the lowest: compounds 2, 3 and 1 (each within the scatter of the next).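

In this assay, 1-benzofuran-2-yl on the triple-bonded carbon gives a number 3 percentage points higher from compound 2 to compound 3 (within the scatter), and a number 7 percentage points lower from compound 1 to compound 3 (within the scatter). The position now holds a group with a five-membered aromatic ring and a hydrogen-bond acceptor, yet neither step separates it from the two phenyl groups. No supporting data bear on this result.

As far as these compounds go, it remains open whether an amine, a carboxylic acid or a longer alkyl chain on the triple-bonded carbon would give a number beyond the scatter of these three compounds.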